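Swapping Selenium for Sulfur at the End of the Chain

A few compounds are considered here, and "the series" means these few. Any claim that something is new, unique, unknown or untested is made for them only; others in the source may bear on it.

Compound 1 `CC(=O)Oc1ccccc1C(=O)NCC[Se]C#N`: 2100 nM
Compound 2 `CC(=O)Oc1ccccc1C(=O)[Se]CC[Se]C(=O)c1ccccc1OC(C)=O`: 5500 nM

Of the two measured compounds, compound 1 shows the lowest number in a functional assay on HT-29 cells (Homo sapiens) for antiproliferative activity, read by MTT assay, with a stated time of 72 h; a lower number here means a stronger inhibitor, a higher number a weaker inhibitor. In this assay compound 1 gives 2100 nM, while compound 2 gives 5500 nM, a higher number that lies beyond the usual scatter.

Compound 3 `CC(=O)Oc1ccccc1C(=O)NCCSC#N` differs from compound 1 by a group of 3 heavy atoms (1 carbon, 1 nitrogen, 1 sulfur; no ring) in place of a group of 3 heavy atoms (1 carbon, 1 nitrogen, 1 selenium; no ring), on a saturated chain carbon, two bonds along the chain from an amide-type nitrogen. Going by the values given here, no measured pair shows a change of this kind, so the size of the step rests on expectation alone. The change is expected to raise the number, a step of a 2.4-fold higher number from compound 1 to compound 3 (0.38 log units; beyond the scatter) that goes beyond the scatter yet stays moderate. Compound 3 is estimated at 5000 nM, within a range from 1500 nM to 15000 nM.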

Compound 3, half-maximal inhibitory concentration: > 50000 nM
Compound 3: only a limit was reported; the forecaster's own chance of this, stated with the estimate: 10%; at least 10-fold (1.00 log units) between middle value and limit.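

Exchanging selenium for sulfur on this saturated chain carbon gives an at least 23-fold higher number from compound 1 to compound 3 (1.37 log units; beyond the scatter) in this assay, so the step is large and the selenium atom matters at this position. The earlier compounds shown here offered no measured change of this kind. The figure for compound 3 is a limit and not a number: the limit of > 50000 nM in this assay, at which 1 of the 3 values shown sits.

The compounds shown leave open how large the step truly is and what lies behind it. They also leave open whether a tellurium atom or a longer chain at this place would keep the activity seen with selenium.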